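The source may report more compounds than this note shows. Statements on the series, on what has been measured and on what is new or still open speak of the compounds shown alone.

In a functional assay on the whole organism with Mus musculus as the target (a lower number here means that less compound is needed, a higher number that more compound is needed for the effect), compound 1 `Cc1c(C)c2c(c(C)c1N)CC(C)(CSc1ccccc1)O2` gives 24.7 mg/kg and compound 3 `Cc1c(C)c2c(c(C)c1N)CC(C)(CSc1ccncc1)O2` gives 19.9 mg/kg, so these two stand level within the scatter. Compound 2 `Cc1c(C)c2c(c(C)c1N)CC(C)(CSc1ccc(O)cc1)O2` gives > 50 mg/kg, which is a limit of the assay and not a number. Compound 4 `Cc1c(C)c2c(c(C)c1N)CC(C)(CSc1nccn1C)O2` carries 1-methyl-1H-imidazol-2-yl in place of pyridin-4-yl on a sulfur. Among the measured compounds shown here, the closest precedent is another exchange of the aromatic ring on that sulfur, which gave a 1.2-fold lower number from compound 1 to compound 3 (0.09 log units; within the scatter). The larger at least 2.5-fold lower number from compound 2 to compound 3 (0.40 log units; beyond the scatter) starts from a limit and involves the hydroxy group, so it bears less directly. The expected result in this assay is therefore a 1.1-fold higher number from compound 3 to compound 4 (0.02 log units; within the scatter), with no change beyond the scatter. For compound 4 the estimate is 21 mg/kg, with an expected range of 10 mg/kg to 45 mg/kg.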

Compound 4, dose for 50% inhibition: 37.1 mg/kg
Compound 4: middle estimate off by 1.8-fold (0.25 log units), on the low side; low and high end bracket the measured number.
By their numbers in this assay, from the lowest: compounds 3, 1 and 4 (each within the scatter of the next). At a limit, above all of these: compound 2.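

In this assay, a five-membered aromatic ring on this sulfur, 1-methyl-1H-imidazol-2-yl, gives a 1.9-fold higher number from compound 3 to compound 4 (0.27 log units; within the scatter) and a 1.5-fold higher number from compound 1 to compound 4 (0.18 log units; within the scatter). This position therefore takes a five-membered ring with a methyl group as well as the six-membered rings of compound 1 and compound 3, with no step beyond the scatter. The step of an at least 1.3-fold lower number from compound 2 to compound 4 (0.12 log units; that floor lies within the scatter) gives only a floor, since the value of compound 2 is a limit and not a number: the limit of > 50 mg/kg in this assay, at which 1 of the 4 values shown sits.

As far as these compounds go, what an amine, a carboxylic acid or a plain alkyl chain would do on this sulfur stays open.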